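The compounds below may be only part of what the source reports. "The series", "measured", "known", "first", "only" and "open" are said of these compounds alone.

Measured so far in a functional assay on UACC-62 cells (Homo sapiens) for cytotoxicity, read by sulforhodamine B assay; on this read-out lower numbers stand for stronger inhibition of growth and higher numbers for weaker inhibition of growth:
compound 1 `CC1=CC[C@@H]([C@@](C)(O)CCCC(C)(C)NC(=S)N/N=C\c2ccccc2)CC1` gives 43800 nM
compound 2 `CC1=CC[C@@H]([C@@](C)(O)CCCC(C)(C)NC(=S)N/N=C\c2ccc(C)cc2)CC1` gives 39000 nM

Among the compounds with values here, compound 2 stands at the lowest of the two numbers, yet the only step toward it, a 1.1-fold lower number from compound 1 to compound 2 (0.05 log units; within the scatter), lies within the scatter, so no order between compound 1 and compound 2 can be claimed. Compound 3 `CC1=CC[C@@H]([C@@](C)(O)CCCC(C)(C)NC(=S)N/N=C\c2cccc(Cl)c2)CC1` differs from compound 2 in one place: 3-chlorophenyl in place of 4-methylphenyl on a carbon with a double bond to nitrogen. Within the data shown here, the single measured step, a 1.1-fold lower number from compound 1 to compound 2 (0.05 log units; within the scatter), also concerns the group on this carbon and was flat, but it does not involve a chlorine, so it bears only loosely on the change. Among the measured compounds shown here, no step shows any movement beyond the scatter, and the expectation for this assay is therefore no shift beyond the scatter, with a wide allowance in either direction. Compound 3 is expected to give about 36000 nM, within a range of 15000 nM to 85000 nM. The estimated step of a 1.1-fold lower number from compound 2 to compound 3 (0.03 log units; within the scatter) is meant to stay within the scatter.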

Compound 3, concentration for total growth inhibition: 18100 nM
The estimate for compound 3 lay 2.0-fold (0.30 log units) above the measured number; the range from low to high includes it.
By their numbers in this assay, from the lowest: compound 3; then compounds 2 and 1 (each within the scatter of the next).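

In this assay, the group on the carbon with a double bond to nitrogen now moves the number beyond the scatter, with a modest step of (a 2.2-fold lower number from compound 2 to compound 3 (0.33 log units; beyond the scatter)) and a similarly modest one of (a 2.4-fold lower number from compound 1 to compound 3 (0.38 log units; beyond the scatter)). Methyl in place of hydrogen on an aromatic carbon had left the number flat (a 1.1-fold lower number from compound 1 to compound 2 (0.05 log units; within the scatter)), whereas chloro in place of hydrogen shifts it, so among these three compounds what this aromatic ring carries can matter. Nothing available explains the shift.

The compounds shown leave open whether the chlorine itself or its place on the ring accounts for the step, a question that a 4-chlorophenyl group would address. They also leave open how a methoxy group, a nitrile or an amine on this ring would read.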